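This account rests on a few compounds, and the source may have more. Where it says the series, first, only, none or still open, it means among the compounds named here.

Two pairs of compounds share one change at the outer aromatic ring. Compound 1 `N#Cc1ccc(-c2cncc(-c3cc4ccc(O)cc4[nH]3)c2)cc1` carries a cyano group there; in a functional assay on NCI60 cells (Homo sapiens) for cytotoxicity, with a stated time of 48 h (on this read-out lower numbers stand for stronger inhibition and higher numbers for weaker inhibition), compound 1 gives 25000 nM. Compound 2 `CS(=O)(=O)c1ccc(-c2cncc(-c3cc4ccc(O)cc4[nH]3)c2)cc1` differs from compound 1 only in this group, (methylsulfonyl in place of cyano on an aromatic carbon), and in this assay compound 2 gives 7000 nM. That single exchange produced a 3.6-fold lower number from compound 1 to compound 2 (0.55 log units; beyond the scatter).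

Compound 3 `N#Cc1ccc(-c2cncc(-c3cc4ccc(O)cc4[nH]3)n2)cc1` keeps the cyano group but is built on a different central ring; how its core differs from that of compound 1 is not broken down here. In this assay compound 3 gives 9000 nM. Compared with the other measured compounds, compound 3 sits close to compound 2 and somewhat apart from compound 1.

Compound 4 `CS(=O)(=O)c1ccc(-c2cncc(-c3cc4ccc(O)cc4[nH]3)n2)cc1` has not yet been measured. It stands to compound 3 as compound 2 stands to compound 1, with the same change in the same place: methylsulfonyl in place of cyano on an aromatic carbon. Since the exchange is identical in group and in position, the expectation rests on what it did once before. The step from compound 3 to compound 4 is expected to be about a 3.0-fold lower number from compound 3 to compound 4 (0.48 log units; beyond the scatter), following the step seen from compound 1 to compound 2, which was a 3.6-fold lower number from compound 1 to compound 2 (0.55 log units; beyond the scatter), with some allowance for a different core giving a smaller response. On that basis compound 4 is estimated to give 3000 nM in this assay, expected to lie between 1200 nM and 8000 nM.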

Compound 4, half-maximal inhibitory concentration: 20000 nM
The estimate for compound 4 lay 6.7-fold (0.82 log units) below the measured number, outside the stated range (above it).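

Replacing cyano with methylsulfonyl on the core of compound 3 gave a 2.2-fold higher number from compound 3 to compound 4 (0.35 log units; beyond the scatter) in this assay, so the exchange that lowered the number on the first core raised it on the second, and the two steps clearly differ: the same change on two cores in this assay, a 3.6-fold lower number (0.55 log units; beyond the scatter) from compound 1 to compound 2 and a 2.2-fold higher number (0.35 log units; beyond the scatter) from compound 3 to compound 4, 7.9-fold (0.90 log units) apart, beyond the scatter of two such steps For these two cores, then, the result of this exchange depends on the core that carries it, and a gain seen on one core cannot simply be assumed on the other. Among these compounds, the data do not show what it is about the two cores that reverses the direction, and with only one matched pair on each core they cannot say how the same exchange would behave on a third core.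

On these data alone, it remains open whether this reversal is particular to cyano and methylsulfonyl or would also appear with other groups in the same place, such as an amine, a carboxylic acid or a longer chain. As far as these compounds go, it also remains open whether any such group would give a step in the same direction on both cores, which would make its effect easier to carry from one core to the other.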